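Adding a Chloro Group to Compound 2

A few compounds are considered here, and "the series" means these few. Any claim that something is new, unique, unknown or untested is made for them only; others in the source may bear on it.

In a functional assay on SK-MEL-2 cells (Homo sapiens) for inhibition, read by sulforhodamine B assay, with a stated time of 48 h (a lower number here means a stronger inhibitor of growth, a higher number a weaker inhibitor of growth), the entry for compound 1 (`NC(=O)c1cc(Br)ccc1NC(=O)/C=C/c1ccccc1`) reads "not determined" (no result reported), so it offers no comparison. Compound 2 (`NC(=O)c1cc(I)ccc1NC(=O)/C=C/c1ccccc1`) gives 1400 nM. Among the measured compounds shown here, this is the only number available, so compound 2 cannot yet be ranked against any close relative. Compound 3 (`NC(=O)c1cc(I)ccc1NC(=O)/C=C/c1ccccc1Cl`) keeps the structure of compound 2 with a single change: chloro in place of hydrogen on an aromatic carbon. In words, this is chloro in place of hydrogen on an aromatic carbon, ortho to a large group, which turns phenyl into 2-chlorophenyl. For the measured compounds named here, no measured pair shows what such a change does in this assay, so the data suggest no direction, and nothing beyond the usual scatter of repeated measurements is expected. The expected change is a 1.1-fold lower number from compound 2 to compound 3 (0.03 log units; within the scatter). For compound 3, the estimated value is 1300 nM, within an expected range of 400 nM to 4000 nM.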

Compound 3, concentration for 50% growth inhibition: 678 nM
Beside the measured number, compound 3's estimate is 1.9-fold (0.28 log units) above it, and the stated range covers the measured number.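

In this assay, among the compounds shown here, the change gives a 2.1-fold lower number from compound 2 to compound 3 (0.31 log units; beyond the scatter) and so provides the first measured comparison in this small set: 2-chlorophenyl in place of phenyl brings a modest gain in growth inhibition, just beyond the usual scatter of repeated measurements. It shows that this aromatic carbon, ortho to a large group, can take a chloro group without loss of growth inhibition, something compound 2 alone could not reveal. Nothing available explains this gain.

Still open, going by these compounds, is whether the gain is particular to chloro, or whether a fluoro, methyl or methoxy group in the same place would match it. Also open, on these data alone, is whether chloro would give a similar result on another carbon of this ring.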